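The compounds below may be only part of what the source reports. "The series", "measured", "known", "first", "only" and "open" are said of these compounds alone.

Compound 1 `CN1CCC[C@H]1COc1cccnc1I`: 606 nM
Compound 2 `CCN(CC)C(=O)c1ccncc1OC[C@@H]1CCCN1C`: 2830 nM

Of these two, compound 2 gives the higher number in an assay on membranes from brain for displacement of a labelled ligand from Neuronal acetylcholine receptor; alpha4/beta2 (Rattus norvegicus); on this read-out lower numbers stand for stronger inhibition and higher numbers for weaker inhibition; compound 1 stands well below it, beyond the scatter. Compound 3 `CN1CCC[C@H]1COc1cnccc1Br` is not yet measured. It differs from compound 2 in one way: bromo in place of diethylcarbamoyl on an aromatic carbon. Among the measured compounds shown here, no measured pair shows this exact change, so its size is uncertain. Compound 1, which also carries a single halogen on its core, gives 606 nM, and compound 3 is expected to move toward that figure. The step from compound 2 to compound 3 is expected to be a 7.1-fold lower number from compound 2 to compound 3 (0.85 log units; beyond the scatter), a decrease beyond the scatter. Compound 3 is expected to give 400 nM, within 80 nM to 2000 nM.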

Compound 3, inhibition constant: 28 nM
Estimate against measurement, compound 3: 14-fold (1.15 log units) above, outside the stated range (below it).
By their numbers in this assay, from the lowest: compound 3; then compound 1; then compound 2.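

Bromo in place of diethylcarbamoyl on this aromatic carbon gives a 100-fold lower number from compound 2 to compound 3 (2.00 log units; beyond the scatter) in this assay and so shows that this position, opposite the ring nitrogen, responds strongly to the group it carries. The earlier compounds shown here could not show that a single bromine atom here does far better than diethylcarbamoyl with its seven heavy atoms. Nothing shown explains why the number falls so far. From the compounds shown here alone, whether chloro, methyl or an amine on this same carbon would keep the low number stays open.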